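The source may hold more compounds than are shown below. What is called first, only, known or untested is meant among the compounds shown, and "the series" means these compounds.

Working notes on the series.

Compound 1 `Cc1cc(C)c(S(=O)(=O)N2CCC(c3ccccc3)CC2)c(C)c1` carries a phenyl group on the saturated carbon of its core. In a functional assay on DLD-1 cells (Homo sapiens) for antiproliferative activity, read by CellTiter-Glo, with a stated time of 72 h (a lower number here means a stronger inhibitor, a higher number a weaker inhibitor), compound 1 gives > 5000 nM, which is a limit of the assay rather than a measured number. Compound 1 therefore sits at the limit of > 5000 nM in this assay, at which 1 of the 2 values shown sits, and has no place on the scale that can be pinned down more closely. Among the compounds with values here, compound 2 `Cc1ccc(S(=O)(=O)N2CCC(N3CCC(C)CC3)CC2)cc1C` is built differently at several points, and in this assay compound 2 gives 24 nM; no single step connects it to compound 1, so its value is noted only for itself.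

Compound 3 `Cc1cc(C)c(S(=O)(=O)N2CCC(C3OCC(C)CO3)CC2)c(C)c1` is the next compound to be measured in this assay. It departs from compound 1 in one place: a group of 7 heavy atoms (5 carbon, 2 oxygen; one six-membered non-aromatic ring with 2 hetero atoms) in place of a group of 6 heavy atoms (6 carbon; one six-membered aromatic ring of carbon only), on a saturated ring carbon.

Within the data shown here, no measured step of this kind exists in the set. Among the measured compounds shown here, compound 1 lies at the limit, so any real gain in this assay would have to be large to show at all, and no step supports such a gain. The step from compound 1 to compound 3 is estimated as a step that the limit leaves unreadable from compound 1 to compound 3, that is, no change beyond the scatter, with the result most likely remaining at the limit. For compound 3 the expected value in this assay is 6000 nM, in a range of 1500 nM to 25000 nM.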

Compound 3, half-maximal inhibitory concentration: > 5000 nM
Compound 3: a limit, no number (the forecaster's own chance of this, stated with the estimate: 60%); the middle value lies beyond the limit too.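

In this assay compound 3 gives > 5000 nM, which is a limit and not a number. No step can be read between compound 1 and compound 3, since both stand at the same limit: the limit of > 5000 nM in this assay, at which 2 of the 3 values shown sit. The compounds shown leave open how far either lies beyond that limit, and whether exchanging the phenyl group changes activity at all.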